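The source may hold more compounds than are shown below. What is called first, only, known or untested is meant among the compounds shown, and "the series" means these compounds.

Among the compounds with values here, in an assay on thoracic aorta (strain Wistar) for antagonist activity at Adrenergic receptor alpha-1 (Rattus norvegicus), with a stated time of 30 min (on this read-out higher numbers stand for weaker binding and lower numbers for tighter binding), compound 1 `COc1cc2nc(CNc3ccccc3)nc(N)c2cc1OC` gives 0.135 nM, and compound 2 `COc1cc2nc(CNc3ccc([N+](=O)[O-])cc3)nc(N)c2cc1OC` gives 0.417 nM, the higher of the two numbers; the one step so far, a 3.1-fold higher number from compound 1 to compound 2 (0.49 log units; beyond the scatter), is modest. Compound 3 `COC(=O)c1ccc(NCc2nc(N)c3cc(OC)c(OC)cc3n2)cc1` differs from compound 2 by methoxycarbonyl in place of nitro on an aromatic carbon. The step to compound 2 bears on this only loosely, since it shows what a group did against hydrogen at this place, not what swapping one such group for another does. Exchanging nitro for methoxycarbonyl is therefore expected to shift this assay little, if at all, a 1.0-fold lower number from compound 2 to compound 3 (0.02 log units; within the scatter). For compound 3 the estimate is 0.4 nM, with a range from 0.15 nM to 1.2 nM.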

Compound 3, dissociation constant: 138 nM
Estimate against measurement, compound 3: 350-fold (2.54 log units) below; the measured number lies above the stated range.
By their numbers in this assay, from the lowest: compound 1; then compound 2; then compound 3.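

In this assay this position does not treat its substituents alike: a 330-fold higher number from compound 2 to compound 3 (2.52 log units; beyond the scatter) separates methoxycarbonyl from nitro, although both groups count the same hydrogen-bond donors and acceptors. Against hydrogen, methoxycarbonyl gives a 1000-fold higher number from compound 1 to compound 3 (3.01 log units; beyond the scatter) and so stands far from the modest step seen with nitro. No measurement at hand gives a reason for this difference.

Left open is whether a carboxylic acid, an amide or an amine at this place would stay close to compound 1 and compound 2 or fall with compound 3.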